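Swapping the Aryl Group on the Benzylic Carbon

The compounds below may be only part of what the source reports. "The series", "measured", "known", "first", "only" and "open" are said of these compounds alone.

Compound 1 `Nc1cc(N)c2nc(-c3ccccc3)c(NCc3ccc(Cl)c(Cl)c3)nc2c1` gives 67600 nM in a functional assay on UACC-62 cells (Homo sapiens) for inhibition, read by sulforhodamine B assay, with a stated time of 48 h; on this read-out lower numbers stand for higher toxicity in this test and higher numbers for lower toxicity in this test.
Compound 2 `Nc1cc(N)c2nc(-c3ccccc3)c(Oc3ccc(F)cc3)nc2c1` gives 69200 nM in this assay.
Compound 3 `COc1ccc(CNc2nc3cc(N)cc(N)c3nc2-c2ccccc2)cc1OC` gives 53700 nM in this assay.

The three measured compounds share one core and differ only in the group attached to it. The number for compound 3 sits within the usual scatter of both compound 1 and compound 2, so on these measurements the three cannot be told apart; none of them can be called more or less toxic than another in this assay.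

Compound 4 `Nc1cc(N)c2nc(-c3ccccc3)c(NCc3ccc(F)cc3)nc2c1` is the next compound to be measured. It differs from compound 3 in one place: 4-fluorophenyl in place of 3,4-dimethoxyphenyl on a saturated chain carbon bound to a nitrogen on an aromatic ring.

For the measured compounds named here, only one measured step touches the same place: a 1.3-fold lower number from compound 1 to compound 3 (0.10 log units; within the scatter). That exchange of one aryl group for another on the saturated chain carbon bound to a nitrogen on the aromatic ring left the number essentially where it was. Because that step a 1.3-fold lower number from compound 1 to compound 3 (0.10 log units; within the scatter) stayed within the scatter, a further exchange of the aryl group in this position is expected to do the same, and the step of a 1.2-fold higher number from compound 3 to compound 4 (0.06 log units; within the scatter) is estimated to lie within the scatter in this assay.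

Compound 4 is therefore expected to give about 62000 nM in this assay, with a likely range from 35000 nM to 110000 nM.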

Compound 4, concentration lethal to 50% of the cells: 56200 nM
Compound 4: middle estimate off by 1.1-fold (0.04 log units), on the high side; low and high end bracket the measured number.
By their numbers in this assay, from the lowest: compounds 3, 4, 1 and 2 (each within the scatter of the next).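

In this assay, 4-fluorophenyl in place of 3,4-dimethoxyphenyl on a saturated chain carbon bound to a nitrogen on an aromatic ring gives a 1.0-fold higher number from compound 3 to compound 4 (0.02 log units; within the scatter), and 4-fluorophenyl in place of 3,4-dichlorophenyl gives a 1.2-fold lower number from compound 1 to compound 4 (0.08 log units; within the scatter), so three different aryl groups at this place cannot now be told apart, even though the group that enters has 7 heavy atoms and 0 hydrogen-bond acceptors, fewer of both than the group that leaves compound 3. The link to the shared core can be exchanged as well without leaving the scatter: (4-fluorobenzyl)amino in place of 4-fluorophenoxy on an aromatic carbon gives a 1.2-fold lower number from compound 2 to compound 4 (0.09 log units; within the scatter). No further measurement is available to account for these results.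

All the groups shown at this place end in a substituted phenyl ring, so it remains open whether an amine or a carboxylic acid on that ring, or a longer chain in place of the saturated chain carbon, would move the number beyond the scatter. Every compound shown also carries the same phenyl group on the shared core, which leaves open what a cyclohexyl group there would do.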